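Working notes: bromo substitution and cytotoxicity in the series

The source may report more compounds than this note shows. Statements on the series, on what has been measured and on what is new or still open speak of the compounds shown alone.

Measured so far:
compound 1 `C/C(=N\NC(=O)COc1cccc2ccccc12)c1ccc(C#N)cc1Br`, 20 ug/mL
compound 2 `C/C(=N\NC(=O)COc1cccc2ccccc12)c1ccccc1`, 20 ug/mL

The read-out throughout is an ADME assay on HEL cells (Homo sapiens) for cytotoxicity; on this read-out higher numbers stand for lower toxicity in this test and lower numbers for higher toxicity in this test. Compound 1 gives 20 ug/mL in this assay, and compound 2 gives 20 ug/mL. The one measured step, phenyl in place of 2-bromo-4-cyanophenyl on a carbon with a double bond to nitrogen, reads no change at the digits printed from compound 1 to compound 2 (within the scatter), so compound 2 stands level with compound 1 at the digits shown.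

Compound 3 `C/C(=N\NC(=O)COc1cccc2ccccc12)c1ccccc1Br` is not yet measured. Against compound 2 the change is bromo in place of hydrogen on an aromatic carbon. For the measured compounds named here, only the step from compound 1 to compound 2 bears on this, and it removed a bromo together with a nitrile without moving the read-out beyond the scatter. Putting a bromo back on its own is therefore expected to give no step beyond the scatter, no change at the digits printed from compound 2 to compound 3 (within the scatter). For compound 3 the estimate in this assay is 20 ug/mL, expected between 10 ug/mL and 40 ug/mL.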

Compound 3, minimum cytotoxic concentration: 20 ug/mL
The estimate for compound 3 equals the measured number at the digits printed, and the stated range covers the measured number.
By their numbers in this assay, from the lowest: compounds 1, 2 and 3 (each within the scatter of the next).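

Bromo in place of hydrogen on an aromatic carbon, ortho to a large group, gives no change at the digits printed from compound 2 to compound 3 (within the scatter) in this assay when taken on its own. Hydrogen in place of cyano on an aromatic carbon gives no change at the digits printed from compound 1 to compound 3 (within the scatter) in the same read-out, so the two substituents removed together in the earlier step now have separate readings, and neither single change moves the number beyond the scatter. No measurement on hand accounts for this flat read-out.

On these data alone, it remains open whether this position stays flat with a group other than bromo, such as an amine, a carboxylic acid or a longer alkyl chain. The compounds shown also leave open whether the same insensitivity holds when the shared core is changed.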